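Changing the Group on the Five-Membered Ring Nitrogen

This account rests on a few compounds, and the source may have more. Where it says the series, first, only, none or still open, it means among the compounds named here.

Of the compounds shown here, three sharing one core have been measured in a functional assay on DU-145 cells (Homo sapiens) for inhibition, read by MTT assay, with a stated time of 24 h; on this read-out lower numbers stand for stronger inhibition and higher numbers for weaker inhibition. Compound 1 `O=C(O)C1=Cc2ccccc2OC1(OCc1cc(-c2ccc(F)cc2)no1)C(F)(F)F` gives 168000 nM in this assay. Compound 3 `O=C(O)C1=Cc2ccccc2OC1(OCc1cc(-c2ccc([N+](=O)[O-])cc2)no1)C(F)(F)F` carries a nitro in place of fluoro on an aromatic carbon and gives 100000 nM in this assay; the step of a 1.7-fold lower number from compound 1 to compound 3 (0.23 log units; within the scatter) is within the scatter. Compound 2 `CCOC(=O)C1=Cc2ccccc2OC1(OCc1cn(CC(=O)Nc2ccc(C)cc2)nn1)C(F)(F)F` gives in this assay only a limit, > 150000 nM. On the numbers shown, compound 2 is therefore the one of the three without a number of its own, standing at the limit of > 150000 nM in this assay, at which 1 of the 3 values shown sits.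

Compound 4 `CCOC(=O)C1=Cc2ccccc2OC1(OCc1cn(-c2ccc(F)c([N+](=O)[O-])c2)nn1)C(F)(F)F` differs from compound 2 in one place: 4-fluoro-3-nitrophenyl in place of ((4-methylphenyl)carbamoyl)methyl on an aromatic nitrogen. The group sits on an aromatic nitrogen of a five-membered aromatic ring with 3 nitrogen.

For the measured compounds named here, no measured step touches this position or this kind of exchange. Going by the values given here, the only measured step, a 1.7-fold lower number from compound 1 to compound 3 (0.23 log units; within the scatter), concerns a different part of the molecule and was within the scatter. With nothing pointing in either direction, the step from compound 2 to compound 4 is expected to be a step that the limit leaves unreadable from compound 2 to compound 4, nothing beyond the scatter. Compound 4 is accordingly estimated at 160000 nM in this assay, within a range from 60000 nM to 450000 nM, and it may well again come back as a limit rather than a number.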

Compound 4, half-maximal inhibitory concentration: 13200 nM
Compound 4: middle estimate off by 12-fold (1.08 log units), on the high side; the measured number lies below the stated range.
By their numbers in this assay, from the lowest: compound 4; then compounds 3 and 1 (each within the scatter of the next).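

The group on the aromatic nitrogen of the five-membered ring clearly counts in this assay: putting 4-fluoro-3-nitrophenyl in place of ((4-methylphenyl)carbamoyl)methyl gives an at least 11-fold lower number from compound 2 to compound 4 (1.05 log units; beyond the scatter). The only earlier step, a 1.7-fold lower number from compound 1 to compound 3 (0.23 log units; within the scatter), concerned a different part of the molecule, so this is the first change in the series to stand out from the usual spread of repeat measurements, and this position is the first shown to respond. The full size of the step cannot be stated because compound 2 reads only as a limit, not as a number: the limit of > 150000 nM in this assay, at which 1 of the 4 values shown sits.

The compounds shown do not separate the parts of this exchange, so it remains unclear whether the fluoro, the nitro or the loss of the amide-bearing chain accounts for the lower number in compound 4. They also leave open how the series would read with an amine in place of the nitro, or with a longer chain carrying the same 4-fluoro-3-nitrophenyl on that nitrogen.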